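The source may report more compounds than this note shows. Statements on the series, on what has been measured and on what is new or still open speak of the compounds shown alone.

Measured so far:
compound 1, `N[C@H]1CC[C@@H](Oc2ccc([C@H]3CC[C@]4(CC3)OOC3(O4)C4CC5CC(C4)CC3C5)cc2)CC1`, < 7 mL.min-1.g-1;
compound 2, `c1cc([C@H]2CC[C@]3(CC2)OOC2(O3)C3CC4CC(C3)CC2C4)ccc1OCC1CCNCC1`, < 7 mL.min-1.g-1;
compound 3, `c1cc([C@H]2CC[C@]3(CC2)OOC2(O3)C3CC4CC(C3)CC2C4)ccc1OCCCNC1CCOCC1`, 10 mL.min-1.g-1.

In an ADME assay on microsomes from liver (Homo sapiens) for metabolic stability, read by LC-MS, tested at 1 uM (on this read-out lower numbers stand for slow clearance and higher numbers for fast clearance), compound 1 gives < 7 mL.min-1.g-1, a limit of the assay rather than a number. Compound 2 likewise gives < 7 mL.min-1.g-1, again a limit. Within the data shown here, compound 3, with 10 mL.min-1.g-1, is therefore the only compound with a number of its own, and it sits at the fast end of what has been seen, as the limit of < 7 mL.min-1.g-1 in this assay, at which 2 of the 3 values shown sit, shows. The steps into it are an at least 1.4-fold higher number from compound 1 to compound 3 (0.15 log units; that floor lies within the scatter) and an at least 1.4-fold higher number from compound 2 to compound 3 (0.15 log units; that floor lies within the scatter), both floors that lie within the scatter.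

The next compound, compound 4, `CC(C)(N)CCOc1ccc([C@H]2CC[C@]3(CC2)OOC2(O3)C3CC4CC(C3)CC2C4)cc1`, differs from compound 3 by 1-amino-1-methylethyl in place of ((oxan-4-yl)amino)methyl on a saturated chain carbon, two bonds along the chain from an oxygen on an aromatic ring. This removes the oxan-4-yl amine that compound 3 alone carries and returns to a smaller amine, as in compounds 1 and 2. Since both steps onto compound 3 raised the number only to a floor within the scatter, the reverse move is expected to bring the number back toward the limit, a 1.4-fold lower number from compound 3 to compound 4 (0.15 log units; within the scatter). Compound 4 is thus estimated at 7 mL.min-1.g-1, in the range 4 mL.min-1.g-1 to 14 mL.min-1.g-1.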

Compound 4, intrinsic clearance in microsomes: < 7 mL.min-1.g-1
Compound 4: no number, only a limit; the forecaster's own chance of this, stated with the estimate: 50%; the middle value sits exactly at the limit.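

In this assay compound 4 gives < 7 mL.min-1.g-1, a limit of the assay and not a number. Putting 1-amino-1-methylethyl in place of ((oxan-4-yl)amino)methyl at this position gives an at least 1.4-fold lower number from compound 3 to compound 4 (0.15 log units; that floor lies within the scatter), so the data fix only a floor for the step, and the steps from compound 1 and compound 2 to compound 4 cannot be read. What is new is that an entering group with no ring also reaches the limit, which leaves compound 3 as the only compound with a number of its own: the limit of < 7 mL.min-1.g-1 in this assay, at which 3 of the 4 values shown sit.

Going by these compounds, how the compounds at the limit rank against one another remains open. So does the outcome for an unbranched 3-aminopropyl group or a carboxylic acid in place of the amine on this chain.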